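This account rests on a few compounds, and the source may have more. Where it says the series, first, only, none or still open, it means among the compounds named here.

Compound 3 `ClCc1ccc(Cn2cnc3c(Cl)nc(Cl)nc32)cc1` is the starting point; in a functional assay on TK-10 cells (Homo sapiens) for cytotoxicity, read by sulforhodamine B assay, with a stated time of 48 h (on this read-out lower numbers stand for stronger inhibition of growth and higher numbers for weaker inhibition of growth), compound 3 gives 6610 nM. Compound 1 `Nc1nc(Cl)c2ncn(Cc3ccc(CCl)cc3)c2n1` differs from it in one place, namely (amino in place of chloro on an aromatic carbon), and in this assay compound 1 gives 16600 nM, so that this change made a 2.5-fold higher number from compound 3 to compound 1 (0.40 log units; beyond the scatter). Compound 2 `ClCc1cccc(Cn2cnc3c(Cl)nc(Cl)nc32)c1` is built from the same atoms as compound 3 joined differently; the difference between the two cores is not broken down here. In this assay compound 2 gives 1730 nM, the lowest of the three measured numbers, with compound 3 nearest to it and compound 1 furthest from it. Compound 4 `Nc1nc(Cl)c2ncn(Cc3cccc(CCl)c3)c2n1` has not yet been measured. It stands to compound 2 as compound 1 stands to compound 3: the change is amino in place of chloro on an aromatic carbon, and the place where it occurs reads the same, word for word, as in the earlier pair. Because the earlier instance of this change gave a 2.5-fold higher number from compound 3 to compound 1 (0.40 log units; beyond the scatter), compound 4 is expected to show a step of about the same size, a 2.5-fold higher number from compound 2 to compound 4 (0.40 log units; beyond the scatter). On that basis compound 4 is estimated at 4300 nM in this assay, with a likely range from 2000 nM to 9500 nM.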

Compound 4, concentration for 50% growth inhibition: 2390 nM
Beside the measured number, compound 4's estimate is 1.8-fold (0.26 log units) above it; the measured number falls inside the stated range.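

In this assay, amino in place of chloro on an aromatic carbon gives a 1.4-fold higher number from compound 2 to compound 4 (0.14 log units; within the scatter), a step within the scatter on this core. Set beside the earlier pair, the step does not differ from it by more than two such steps would scatter: the same change on two cores in this assay, a 2.5-fold higher number (0.40 log units; beyond the scatter) from compound 3 to compound 1 and a 1.4-fold higher number (0.14 log units; within the scatter) from compound 2 to compound 4, 1.8-fold (0.26 log units) apart, within the scatter of two such steps This shows that the change can be carried between these two cores with no difference that can be told apart, but two pairs in a single cell line do not fix its true size, nor do they show that it would hold on any other core or in any other cells.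

The compounds shown leave open whether another group at the same place, such as a methoxy group or a dimethylamino group, would behave as amino does. They also leave open what a replacement of the chloro group that remains in compound 4 would do to the number.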